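The compounds below may be only part of what the source reports. "The series", "measured", "known", "first", "only" and "open" are said of these compounds alone.

Measured in a functional assay on DU-145 cells (Homo sapiens) for inhibition, read by trypan blue exclusion, with a stated time of 96 h; on this read-out higher numbers stand for weaker inhibition of growth and lower numbers for stronger inhibition of growth:
- compound 1 `O=C(/C(=C\c1ccc(O)cc1O)SCc1ccc(Cl)cc1)c1ccc(Cl)cc1`: 50000 nM
- compound 2 `O=C(/C(=C\c1ccc(O)cc1)SCc1ccc(Cl)cc1)c1ccc(Cl)cc1`: 10000 nM

Within the data shown here, of these two numbers, compound 2 holds the lower, and its only neighbour is compound 1. The next structure, compound 3 `O=C(/C(=C\c1ccc[nH]1)SCc1ccc(Cl)cc1)c1ccc(Cl)cc1`, has not yet been measured. It differs from compound 2 as follows: 1H-pyrrol-2-yl in place of 4-hydroxyphenyl on a double-bonded chain carbon bound to a double-bonded chain carbon.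

Among the measured compounds shown here, only one measured step bears on this change, and only indirectly: a 5.0-fold lower number from compound 1 to compound 2 (0.70 log units; beyond the scatter), with hydrogen in place of hydroxy on an aromatic carbon. That step altered the aromatic ring but did not replace it, so no measurement shows what an exchange of the whole ring does. In this assay a step of roughly that modest size is therefore expected, with neither direction clearly favoured, and the expectation stays close to compound 2 at 10000 nM. The expected change is a 1.2-fold higher number from compound 2 to compound 3 (0.08 log units; within the scatter). For compound 3 the estimated value is 12000 nM, with an expected range from 3000 nM to 50000 nM.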

Compound 3, concentration for 50% growth inhibition: 10000 nM
Beside the measured number, compound 3's estimate is 1.2-fold (0.08 log units) above it; low and high end bracket the measured number.
By their numbers in this assay, from the lowest: compounds 2 and 3 (each within the scatter of the next); then compound 1.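

Read in this assay, this is the first exchange of the whole ring at this place, on a double-bonded chain carbon bound to a double-bonded chain carbon, and it gives the following result (no change at the digits printed from compound 2 to compound 3 (within the scatter)). The six-membered 4-hydroxyphenyl ring of carbon only can therefore give way to the smaller five-membered 1H-pyrrol-2-yl ring, with its 1 hetero atom, without any change that can be told from the scatter, so this place does not depend on that particular ring. Set against the 2,4-dihydroxyphenyl ring, the same group gives a step beyond the scatter (a 5.0-fold lower number from compound 1 to compound 3 (0.70 log units; beyond the scatter)), which places compound 3 with compound 2 and leaves compound 1 apart, though nothing given here accounts for this.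

As far as these compounds go, what stays open is whether this tolerance extends to other rings at this place, such as furan-2-yl, pyridin-3-yl or a phenyl ring carrying an amine or a carboxylic acid. From the compounds shown here alone, it is equally open whether the hydrogen on the pyrrole nitrogen matters, which a 1-methyl-1H-pyrrol-2-yl group would test.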